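Replacing Fluoro with Methyl on a Hydroxyamino Compound

The source may hold more compounds than are shown below. What is called first, only, known or untested is meant among the compounds shown, and "the series" means these compounds.

Measured in an ADME assay on HL-60 cells (Homo sapiens) for cytotoxicity, read by MTT assay, with a stated time of 3 days; on this read-out lower numbers stand for higher toxicity in this test and higher numbers for lower toxicity in this test:
- compound 1 `O=c1nc(NO)c(F)cn1[C@@H]1C[C@@H](O)[C@H](CO)O1`: 1370000 nM
- compound 2 `[N-]=[N+]=N[C@@H]1C[C@@H](n2ccc(NO)nc2=O)O[C@H]1CO`: 2000000 nM
- compound 3 `Cc1cn([C@@H]2C=C[C@H](CO)O2)c(=O)nc1N`: 600000 nM

Among these three compounds, compound 1 stands with compound 2 at the high end of the numbers, and the two lie within the scatter of each other. Compound 3 gives a lower number than compound 1, and that gap lies beyond the scatter. On this read-out, compound 3 is therefore the more toxic of that pair.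

The next compound to be tested is compound 4 `Cc1cn([C@@H]2C[C@@H](O)[C@H](CO)O2)c(=O)nc1NO`. Its difference from compound 1 is methyl in place of fluoro on an aromatic carbon, ortho to a hydroxyamino group. Among the measured compounds shown here, no measured pair shows this change on its own, so the size of the step cannot be read directly from the data. Compound 2 also carries a hydroxyamino group and, at 2000000 nM, remains within the scatter of compound 1. No change beyond the scatter is therefore expected in this assay.

The expected 1.1-fold higher number from compound 1 to compound 4 (0.04 log units; within the scatter) is small, with no firm direction. For compound 4 the estimated value is 1500000 nM, with an expected range from 600000 nM to 3500000 nM.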

Compound 4, half-maximal cytotoxic concentration: 600000 nM
Compound 4: the middle estimate sits 2.5-fold (0.40 log units) above what was measured, within the range that was stated.
By their numbers in this assay, from the lowest: compounds 3 and 4 (each within the scatter of the next); then compounds 1 and 2 (each within the scatter of the next).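

In this assay, methyl in place of fluoro on an aromatic carbon, ortho to a hydroxyamino group, gives a 2.3-fold lower number from compound 1 to compound 4 (0.36 log units; beyond the scatter) and so marks compound 4 as the more toxic of this pair, a modest step but one that lies beyond the scatter. Among the compounds shown here, this is the first single-change pair in the set, and it shows that the substituent at this position of the core of compound 1 can by itself shift the read-out, which the earlier compounds, differing from one another in more than one place, could not show. Nothing measured here explains the step, so it stands as an observation without a stated cause.

The compounds shown leave open whether the shift is specific to methyl or would also appear with a chloro or an ethyl group on the same aromatic carbon, so neither a trend with the substituent nor its direction can be drawn from one pair. They also leave open whether the same exchange would give a step of similar size if an amino group stood in place of the hydroxyamino group on the otherwise unchanged core.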